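The source may report more compounds than this note shows. Statements on the series, on what has been measured and on what is new or still open speak of the compounds shown alone.

Measured so far in a functional assay on B16-F10 cells (Mus musculus) for inhibition, with a stated time of 4 days; on this read-out lower numbers stand for stronger inhibition and higher numbers for weaker inhibition:
Compound 1 `COc1cc(O)c(C(=O)/C=C/c2cccc(O)c2)c(OC)c1`: 9900 nM
Compound 2 `COc1cc(O)c(C(=O)/C=C/c2ccccc2O)c(OC)c1`: 2300 nM
Compound 3 `COc1cc(O)c(C(=O)/C=C/c2ccccc2OC)c(OC)c1`: 3800 nM

Compound 2, at 2300 nM, sits at the low end of these numbers, the stronger end of this read-out. It is not separated from the methylated compound, as the data show a 1.7-fold higher number from compound 2 to compound 3 (0.22 log units; within the scatter). It is clearly separated from the other hydroxyl compound, with a 4.3-fold lower number from compound 1 to compound 2 (0.63 log units; beyond the scatter).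

The next compound, compound 4 `COc1cc(O)c(C(=O)/C=C/c2ccc(O)cc2)c(OC)c1`, carries 4-hydroxyphenyl in place of 2-hydroxyphenyl on a double-bonded chain carbon bound to a double-bonded chain carbon. Nothing with a 4-hydroxyphenyl group has been measured yet, so the forecast must lean on neighbouring changes. Among the measured compounds shown here, the closest precedent is the swap of 3-hydroxyphenyl for 2-hydroxyphenyl, which gave a 4.3-fold lower number from compound 1 to compound 2 (0.63 log units; beyond the scatter). That single step shows that the same atoms joined differently can shift the number beyond the scatter. The methyl change bears less directly, since it leaves the group in the same place.

For the measured compounds named here, a modest rise in the number is therefore expected, smaller than or similar to the one step of this kind seen so far. The expected size is a 2.4-fold higher number from compound 2 to compound 4 (0.38 log units; beyond the scatter). For compound 4 the estimate is 5500 nM, with an expected range from 1800 nM to 16000 nM.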

Compound 4, half-maximal inhibitory concentration: 6900 nM
Beside the measured number, compound 4's estimate is 1.3-fold (0.10 log units) below it, and the stated range covers the measured number.
By their numbers in this assay, from the lowest: compounds 2, 3, 4 and 1 (each within the scatter of the next, the first and the last beyond it).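

With the hydroxyl group now seen in three arrangements on the phenyl ring, this assay shows that the arrangement itself matters at this place on the chain, since swapping 2-hydroxyphenyl for 4-hydroxyphenyl changes no atom count yet gives a 3.0-fold higher number from compound 2 to compound 4 (0.48 log units; beyond the scatter) beyond the usual scatter. The other two arrangements, however, cannot be told apart, as 3-hydroxyphenyl and 4-hydroxyphenyl give a 1.4-fold lower number from compound 1 to compound 4 (0.16 log units; within the scatter) and so sit together within the scatter. The three hydroxyphenyl compounds therefore do not form a steady climb as the hydroxyl group changes place: 2-hydroxyphenyl stands apart in compound 2, while compound 1 and compound 4 form a weaker pair.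

Nothing measured here says what lies behind this separation. The compounds shown also leave open whether the stronger number of compound 2 depends on a hydroxyl group at all, or whether an amine or a carboxylic acid on the phenyl ring, carried as 2-aminophenyl or 2-carboxyphenyl at the same place on the chain, would give a similar number in this assay or a clearly different one.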